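Bromo for chloro on a benzyl-bearing core

The compounds below may be only part of what the source reports. "The series", "measured", "known", "first", "only" and "open" are said of these compounds alone.

Measured compounds:
compound 1, `NS(=O)(=O)c1ccc(/N=C2\NC(=O)/C(=C3/C(=O)Nc4ccc(Br)cc43)S2)cc1`, 42300 nM
compound 2, `NS(=O)(=O)c1ccc(/N=C2\NC(=O)/C(=C3/C(=O)N(Cc4ccccc4)c4ccc(Cl)cc43)S2)cc1`, 13700 nM

Both compounds were tested in a functional assay on Caco-2 cells (Homo sapiens) for antiproliferative activity, read by MTT assay; on this read-out lower numbers stand for stronger inhibition and higher numbers for weaker inhibition. Among the two numbers, compound 2 has the lower one, and the nearest is compound 1, whose value is higher by a margin beyond the usual scatter. The two compounds differ in more than one place, so their two values alone cannot be tied to a single change.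

Compound 3, `NS(=O)(=O)c1ccc(/N=C2\NC(=O)/C(=C3/C(=O)N(Cc4ccccc4)c4ccc(Br)cc43)S2)cc1`, has not yet been measured. It differs from compound 2 in one place only: bromo in place of chloro on an aromatic carbon. On these data alone, compound 1 already carries a bromo at this position on a core without the benzyl group, but no single-change comparison between measured compounds exists here, so the size of this exchange is unknown. A swap of one halogen for another of this kind is usually small, and no step beyond the scatter is expected in this assay, in either direction. The value expected for compound 3 is 12000 nM, within a range from 5000 nM to 30000 nM, which means an expected step of a 1.1-fold lower number from compound 2 to compound 3 (0.06 log units; within the scatter).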

Compound 3, half-maximal inhibitory concentration: 57800 nM
For compound 3 the middle estimate is 4.8-fold (0.68 log units) below the measured one; measured number above the stated range.
By their numbers in this assay, from the lowest: compound 2; then compounds 1 and 3 (each within the scatter of the next).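

In this assay, the identity of the halogen on this aromatic carbon turns out to matter: on the benzyl-bearing core, bromo in place of chloro gives a 4.2-fold higher number from compound 2 to compound 3 (0.63 log units; beyond the scatter) and so weakens inhibition, even though only one atom is exchanged. The second new pair isolates the group on the amide-type nitrogen in a ring, and with bromo on the aromatic carbon, benzyl in place of hydrogen gives a 1.4-fold higher number from compound 1 to compound 3 (0.14 log units; within the scatter) and so has no effect that can be told apart from the scatter. Nothing measured on these compounds explains the loss of inhibition seen on going from chloro to bromo.

The compounds shown have no chloro partner without the benzyl group, so it remains open whether the halogen step is the same size on a core that keeps the amide hydrogen. Also open, on these data alone, is how inhibition would respond to a fluoro, a methoxy or an amine on this aromatic carbon, or to a phenethyl group in place of benzyl on the nitrogen.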